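Swapping cyclohexyl for isopropyl in an antiproliferative series

The source may report more compounds than this note shows. Statements on the series, on what has been measured and on what is new or still open speak of the compounds shown alone.

Compound 1 `C/C=C1/[C@H](O[C@@H]2O[C@H](CO)[C@@H](O)[C@H](O)[C@H]2O)OC=C(C(=O)OC)[C@H]1CC(=O)OCCCCCCCCCCCCCCC`: 380 nM
Compound 2 `C/C=C1/[C@H](O[C@@H]2O[C@H](COC(C)=O)[C@@H](OC(C)=O)[C@H](OC(C)=O)[C@H]2OC(C)=O)OC=C(C(=O)OC)[C@H]1CC(=O)OCCCCCCCCCCCCCCC`: 8000 nM
Compound 3 `C/C=C1/[C@H](O[C@@H]2O[C@H](CO)[C@@H](O)[C@H](O)[C@H]2O)OC=C(C(=O)OC)[C@H]1CC(=O)OCCC1CCCCC1`: 480 nM

In a functional assay on HL-60 cells (Homo sapiens) for antiproliferative activity, read by MTT assay, with a stated time of 72 h (a higher number here means a weaker inhibitor, a lower number a stronger inhibitor), compound 3 lies within the usual scatter of compound 1 and far beyond that scatter from the much higher number of compound 2. Compound 4 `C/C=C1/[C@H](O[C@@H]2O[C@H](CO)[C@@H](O)[C@H](O)[C@H]2O)OC=C(C(=O)OC)[C@H]1CC(=O)OCCC(C)C` has isopropyl in place of cyclohexyl on a saturated chain carbon, two bonds along the chain from an oxygen next to a carbonyl group. For the measured compounds named here, no measured pair differs only at this place, so the guide is indirect. Compound 1, at 380 nM, and compound 3, at 480 nM, carry different groups at this end, yet their values stay within scatter of each other. The estimated step is a 1.9-fold higher number from compound 3 to compound 4 (0.27 log units; within the scatter), a modest rise in the number, which would mean a somewhat weaker inhibitor. For compound 4 the estimate is 900 nM, with an expected range of 350 nM to 3000 nM.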

Compound 4, half-maximal inhibitory concentration: 9830 nM
The estimate for compound 4 lay 11-fold (1.04 log units) below the measured number, outside the stated range (above it).
By their numbers in this assay, from the lowest: compounds 1 and 3 (each within the scatter of the next); then compounds 2 and 4 (each within the scatter of the next).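

In this assay isopropyl in place of cyclohexyl brings a 20-fold higher number from compound 3 to compound 4 (1.31 log units; beyond the scatter) and so a much weaker inhibitor. This place, on a saturated chain carbon, two bonds along the chain from an oxygen next to a carbonyl group, therefore responds strongly to the group it carries. The close values of compound 1 and compound 3 gave no sign of this.

Nothing measured here explains the step. As far as these compounds go, whether a phenyl or cyclopentyl group at this place would keep the lower number of compound 3 remains open.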